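The compounds below may be only part of what the source reports. "The series", "measured", "known", "first", "only" and "open" are said of these compounds alone.

Compound 1 `CC[C@H](C)C(=O)O[C@H]1CCC=C2C=C[C@H](C)[C@H](COC(=O)C[C@@H](O)CC(=O)O)[C@H]21` gives 630 nM in an assay on microsomes from liver for inhibition of 3-hydroxy-3-methylglutaryl-coenzyme A reductase (Rattus norvegicus); on this read-out higher numbers stand for weaker inhibition and lower numbers for stronger inhibition.
Compound 2 `CC[C@H](C)C(=O)O[C@@H]1CCC=C2C=C[C@@H](C)[C@@H](COC(=O)C[C@@H](O)CC(=O)O)[C@@H]21` gives only a limit in this assay, namely > 25000 nM.

Compound 2 therefore stands at the edge of what this assay can report: no number is known for it, only a limit (the limit of > 25000 nM in this assay, at which 1 of the 2 values shown sits). Among the measured compounds shown here, the one measured step that bears on it, an at least 39-fold higher number from compound 1 to compound 2 (1.59 log units; beyond the scatter), rests on a change of configuration alone (the fact that compounds 1 and 2 differ only in the configuration as drawn). Compound 3 `CC[C@H](C)C(=O)O[C@@H]1CCC=C2C=C[C@@H](C)[C@@H](COC(=O)C[C@H](O)CC(=O)O)[C@@H]21` again differs from compound 2 in configuration only: the two compounds have the same atoms and bonds and differ only in configuration as drawn: 1 of 6 stereo elements differ; a stereocentre at a saturated chain carbon is drawn S in compound 2 and R in compound 3. For the measured compounds named here, no measured step shows what inverting this chain stereocentre does of compound 2, and the only stereochemical step at hand, an at least 39-fold higher number from compound 1 to compound 2 (1.59 log units; beyond the scatter), was large. Compound 3 is thus expected to stay weak in this assay, and the step of an at least 1.2-fold lower number from compound 2 to compound 3 (0.09 log units; that floor lies within the scatter) is an estimate whose direction is open. The estimate for compound 3 in this assay is 20000 nM, with a range from 4000 nM to 100000 nM.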

Compound 3, half-maximal inhibitory concentration: 25000 nM
Beside the measured number, compound 3's estimate is 1.3-fold (0.10 log units) below it; low and high end bracket the measured number.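

In this assay, among the compounds shown here, compound 3 gives 25000 nM, the first real number for this set of ring configurations, and inverting the chain stereocentre gives a number no higher from compound 2 to compound 3 (the limit leaves the size open), which does not bring back the inhibition seen for compound 1. The gap is a 40-fold higher number from compound 1 to compound 3 (1.60 log units; beyond the scatter), and it rests on configuration alone: the fact that compounds 1 and 3 differ only in the configuration as drawn
Compound 2 has only a limit, > 25000 nM, so the size of the step that carries the chain inversion alone cannot be read.

The compounds shown leave open what inverting this chain stereocentre does when the ring stereocentres stay as drawn in compound 1, the one setting where a change could be measured against a real number. They also leave open how an amine or a methoxy group in place of the hydroxyl on that chain carbon would read out in this assay.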